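From benzyloxy to phenoxy: estimating the stability of compound 3

The compounds below may be only part of what the source reports. "The series", "measured", "known", "first", "only" and "open" are said of these compounds alone.

Compound 1 `Cc1nc2cc(-c3ccccc3)nn2c(N2CCC(C)(C)CC2)c1C(OC(C)(C)C)C(=O)O` gives 100%
Compound 2 `Cc1nc2cc(-c3cccc(OCc4ccccc4)c3)nn2c(-c2cc(F)c3c(c2C)CCCO3)c1C(OC(C)(C)C)C(=O)O` gives 72%

In an ADME assay on microsomes from liver (Homo sapiens), read by LC-MS, using NADPH, with a stated time of 10 min, tested at 0.5 uM (on this read-out lower numbers stand for a less stable compound and higher numbers for a more stable compound), compound 2 stands at 72% as the lower of the two numbers, and compound 1 lies higher by a gap beyond the usual scatter. These two compounds differ in more than one place, so their gap cannot be pinned on any single group.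

Compound 3 `Cc1nc2cc(-c3cccc(Oc4ccccc4)c3)nn2c(-c2cc(F)c3c(c2C)CCCO3)c1C(OC(C)(C)C)C(=O)O` is compound 2 with phenyl in place of benzyl on an oxygen on an aromatic ring, the one difference between them. Among the compounds with values here, no measured pair shows this change, so the expectation is loose: a small rise in this assay at most, with no move beyond the scatter. The expected step is a number 6 percentage points higher from compound 2 to compound 3 (within the scatter) and it would sit within the scatter. For compound 3 the estimated value is 78% (range 62% to 94%).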

Compound 3, percent of the compound remaining: 100%
Compound 3: middle estimate off by 22 percentage points, on the low side; the whole stated range lies below it.
By their numbers in this assay, from the lowest: compound 2; then compounds 1 and 3 (each within the scatter of the next).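

In this assay the exchange of benzyl for phenyl on an oxygen on an aromatic ring gives a number 28 percentage points higher from compound 2 to compound 3 (beyond the scatter) with nothing else altered in the structure. Compound 1 and compound 2 differ in more than one place, so they could not show this; here a gap beyond the scatter belongs to one change, in which a group of 7 heavy atoms gives way to one of 6. Nothing available explains why this change moves the number.

From the compounds shown here alone, it remains open how other groups on this oxygen would behave, such as phenethyl with its longer chain, or pyridyl with a ring nitrogen. Also open, going by these compounds, is whether the same exchange would give a similar step in compounds with another group in place of the fluorinated ring system of compound 2.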